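This account rests on a few compounds, and the source may have more. Where it says the series, first, only, none or still open, it means among the compounds named here.

Measured so far in an assay on isolated protein with adenosine receptor A3 (Homo sapiens) as the target, tested at 10 uM; a lower number here means less inhibition, a higher number more inhibition at the concentration tested (going by the name of the read-out):
compound 1 `Nc1sc2c(c1C(=O)c1cccc3ccccc13)CCC2`: 0%
compound 2 `Nc1sc2c(c1C(=O)c1ccc(Cl)c3ccccc13)CCC2`: 0%
compound 3 `Nc1sc2c(c1C(=O)c1ccc(Br)c3ccccc13)CCC2`: 22%

Compound 3 stands highest of the three in this assay, set apart by a number 22 percentage points higher from compound 1 to compound 3 (beyond the scatter) and by a number 22 percentage points higher from compound 2 to compound 3 (beyond the scatter), while no change at the digits printed from compound 1 to compound 2 (within the scatter). Compound 4 `Nc1sc2c(c1C(=O)c1ccc(I)c3ccccc13)CCC2` differs from compound 3 by iodo in place of bromo on an aromatic carbon. The step that bears most directly on this change is the exchange of one halogen for a heavier one, a number 22 percentage points higher from compound 2 to compound 3 (beyond the scatter), which was modest but beyond the scatter, and the unchanged pair no change at the digits printed from compound 1 to compound 2 (within the scatter) shows that the smaller halogen did nothing. A further modest rise is therefore expected for compound 4, as a number 15 percentage points higher from compound 3 to compound 4 (beyond the scatter). Compound 4 is estimated at 37%, within a range of 15% to 60%.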

Compound 4, a percentage reported as inhibition, at one concentration (the size of the read-out at that concentration, not a potency): 0%
Estimate against measurement, compound 4: 37 percentage points above; measured number below the stated range.
By their numbers in this assay, from the lowest: compounds 1, 2 and 4 (each within the scatter of the next); then compound 3.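

In this assay the read-out at this position does not climb with halogen size: a number 22 percentage points lower from compound 3 to compound 4 (beyond the scatter) is the step for iodo in place of bromo. Iodo also stands level with hydrogen and chloro, with no change at the digits printed from compound 1 to compound 4 (within the scatter) and no change at the digits printed from compound 2 to compound 4 (within the scatter) as the steps, so among these four only compound 3, with bromo, stands apart. Nothing available here explains the difference between bromo and iodo.

From the compounds shown here alone, whether a methoxy, an amine or a carboxylic acid at this position would raise the read-out remains open. So does whether bromo would give a similar number elsewhere on the same ring.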